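Swapping a benzyl group for a phenyl group on a pyrimidine amine

This account rests on a few compounds, and the source may have more. Where it says the series, first, only, none or still open, it means among the compounds named here.

Of the compounds shown here, three have been tested in a functional assay on MCF7 cells (Homo sapiens) for inhibition, read by CCK-8 assay, with a stated time of 48 h; on this read-out higher numbers stand for weaker inhibition of growth and lower numbers for stronger inhibition of growth. Compound 1, `Cc1ccccc1Nc1nc(Nc2cccnc2)ncc1Cl`, gives 56500 nM. Compound 2, `CCN1CCN(c2ccc(Nc3ncc(Cl)c(Nc4ccccc4C)n3)cc2)CC1`, gives 3160 nM. Compound 3, `CN1CCN(c2ccc(Nc3ncc(Cl)c(NCc4ccc(C(F)(F)F)cc4)n3)nc2)CC1`, gives 28400 nM. Among these three numbers compound 3 stands second highest: its nearest neighbour is compound 1, whose number is higher but within the scatter of repeated measurements, so the two cannot be told apart, while compound 2 lies furthest away with a number that is lower by a margin beyond the scatter.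

Compound 4, `CC(C)c1cccc(Nc2nc(Nc3ccc(N4CCN(C)CC4)cn3)ncc2Cl)c1`, has not yet been measured. It differs from compound 3 in one place: 3-isopropylphenyl in place of 4-(trifluoromethyl)benzyl on a nitrogen on an aromatic ring. The rest of the shared core is untouched. For the measured compounds named here, no pair of measured compounds differs by exactly this change, so there is no measured step to lean on; the expectation rests on the spread of the three values and on the fact that compound 2 reaches 3160 nM within this series.

On that basis the step in this assay from compound 3 to compound 4 is expected to be a 4.7-fold lower number from compound 3 to compound 4 (0.68 log units; beyond the scatter), towards stronger inhibition and probably beyond the scatter. Compound 4 is therefore estimated at 6000 nM, with a plausible range from 1500 nM to 25000 nM.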

Compound 4, concentration for 50% growth inhibition: 8640 nM
Compound 4: middle estimate off by 1.4-fold (0.16 log units), on the low side; measured number inside the range.
By their numbers in this assay, from the lowest: compound 2; then compound 4; then compounds 3 and 1 (each within the scatter of the next).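

In this assay, replacing 4-(trifluoromethyl)benzyl with 3-isopropylphenyl on this nitrogen gives a 3.3-fold lower number from compound 3 to compound 4 (0.52 log units; beyond the scatter), a modest move towards stronger inhibition and the first measured sign that the group at this place can change the read-out while the rest of the shared core stays fixed. The swap alters more than one feature at once: benzyl becomes phenyl, isopropyl takes over from trifluoromethyl, and the fluorine atoms leave, although each group still has one aromatic ring of carbon only and no hydrogen-bond donors or acceptors, so this single step cannot assign the shift to any one of those features. No measured evidence is available to explain the shift.

The compounds shown leave open how a plain phenyl or a plain benzyl group would read here, and such compounds could help separate the effect of the ring's attachment from that of its substituent. They also leave open whether trifluoromethyl on phenyl, isopropyl on benzyl, or an amine or a carboxylic acid in place of either substituent would move the number further in either direction.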